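Swapping furan-2-yl for 2-methoxyphenyl: what to expect

The source may hold more compounds than are shown below. What is called first, only, known or untested is meant among the compounds shown, and "the series" means these compounds.

- compound 1 `COc1cc(/C=C/C(=O)/C=C/c2cccs2)ccc1OCc1cn(CCOc2cc(=O)oc3ccccc23)nn1`: 11400 nM
- compound 2 `COc1cc(/C=C/C(=O)/C=C/c2ccco2)ccc1OCc1cn(CCOc2cc(=O)oc3ccccc23)nn1`: 11800 nM
- compound 3 `COc1ccccc1/C=C/C(=O)/C=C/c1ccc(OCc2cn(CCOc3cc(=O)oc4ccccc34)nn2)c(OC)c1`: not yet measured

Both numbers come from a functional assay on COLO 205 cells (Homo sapiens) for cytotoxicity, read by sulforhodamine B assay, with a stated time of 48 h; a lower number here means a stronger inhibitor, a higher number a weaker inhibitor. Among the measured compounds shown here, compound 2 cannot be told apart from its only measured neighbour, with a step of a 1.0-fold higher number from compound 1 to compound 2 (0.01 log units; within the scatter). The next change is 2-methoxyphenyl in place of furan-2-yl on a double-bonded chain carbon bound to a double-bonded chain carbon. For the measured compounds named here, only one measured step bears on it, the swap of thiophen-2-yl for furan-2-yl at the same place, and that step stayed within the scatter. It is a limited guide, since it joins two five-membered aromatic rings, while the entering group holds a six-membered aromatic ring of carbon only. No step beyond the scatter is therefore expected, in either direction, though the uncertainty is wide. The expected step is a 1.1-fold lower number from compound 2 to compound 3 (0.03 log units; within the scatter). The estimate for compound 3 is 11000 nM, with an expected range of 4500 nM to 27000 nM.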

Compound 3, half-maximal inhibitory concentration: 11500 nM
Compound 3: middle estimate off by 1.0-fold (0.02 log units), on the low side, within the range that was stated.
By their numbers in this assay, from the lowest: compounds 1, 3 and 2 (each within the scatter of the next).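

In this assay, among the compounds shown here, the earlier pair compared only two five-membered aromatic rings, whereas compound 3 places a six-membered aromatic ring of carbon only, with 8 heavy atoms instead of 5, at this same place on the chain. Even this larger change stays within the scatter, both against the furan-2-yl compound (a 1.0-fold lower number from compound 2 to compound 3 (0.01 log units; within the scatter)) and against the thiophen-2-yl compound (a 1.0-fold higher number from compound 1 to compound 3 (0.00 log units; within the scatter)), so the assay does not separate these three aromatic groups. No measurement offers an explanation for this result.

As far as these compounds go, all three compounds carry an aromatic ring here, so the effect of a non-aromatic group such as an amine, a carboxylic acid or a longer chain remains open. From the compounds shown here alone, whether the methoxy of 2-methoxyphenyl contributes also remains open, a question that plain phenyl could address.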